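Moving the chloro and trifluoromethyl groups on a urea aryl ring

The source may hold more compounds than are shown below. What is called first, only, known or untested is meant among the compounds shown, and "the series" means these compounds.

Compound 1: `CC1CN(C(=O)/C=C/c2ccc(NC(=O)Nc3ccc(Cl)c(C(F)(F)F)c3)cc2)CC(C)O1`, > 50000 nM in a functional assay on KETR3 cells (Homo sapiens) for inhibition, read by MTT assay, with a stated time of 120 h; a lower number here means a stronger inhibitor, a higher number a weaker inhibitor
Compound 2: `CC(NC(=O)/C=C/Oc1ccc(NC(=O)Nc2cc(C(F)(F)F)ccc2Cl)cc1)c1ccccc1`, 16400 nM

Among the compounds with values here, compound 2 gives the only number in this assay. Compound 1 gives only a limit, > 50000 nM, as shown by the limit of > 50000 nM in this assay, at which 1 of the 2 values shown sits. Compound 3, `CC(NC(=O)/C=C/Oc1ccc(NC(=O)Nc2ccc(Cl)c(C(F)(F)F)c2)cc1)c1ccccc1`, differs from compound 2 by 4-chloro-3-(trifluoromethyl)phenyl in place of 2-chloro-5-(trifluoromethyl)phenyl on an amide-type nitrogen. Compound 1 also carries the 4-chloro-3-(trifluoromethyl)phenyl group, though on a different core, so the change gives no clear direction. Compound 3 is expected to stay near compound 2, with a step of a 1.2-fold higher number from compound 2 to compound 3 (0.09 log units; within the scatter) within the scatter, and an estimated 20000 nM (range 6000 nM to 60000 nM).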

Compound 3, half-maximal inhibitory concentration: 14500 nM
Estimate against measurement, compound 3: 1.4-fold (0.14 log units) above; the measured number falls inside the stated range.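

In this assay, 4-chloro-3-(trifluoromethyl)phenyl in place of 2-chloro-5-(trifluoromethyl)phenyl on an amide-type nitrogen gives a 1.1-fold lower number from compound 2 to compound 3 (0.05 log units; within the scatter) on the shared core, so the two arrangements of chloro and trifluoromethyl cannot be told apart here. Compound 1, on a different core, gives only a limit and offered no such comparison. Nothing shown accounts for this result. Still open, from the compounds shown here alone, is whether a methoxy group or a nitrile on this ring would move the value, and whether either arrangement on the core of compound 1 would give a number instead of a limit.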